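A few compounds are considered here, and "the series" means these few. Any claim that something is new, unique, unknown or untested is made for them only; others in the source may bear on it.

Measured compounds:
compound 1 `C[C@@H]1O[C@@H](OCC#Cc2c(-c3ccccc3)oc3ccccc23)CC[C@@H]1N` — in an assay on isolated protein for inhibition of DNA topoisomerase 1 (Homo sapiens), with a stated time of 30 min, tested at 100 uM (a lower number here means less inhibition, a higher number more inhibition at the concentration tested (going by the name of the read-out)), compound 1 gives 20.2%
compound 2 `C[C@@H]1O[C@@H](OCC#Cc2c(-c3ccccc3)oc3ccccc23)C[C@H](N)[C@@H]1O` — compound 2 gives 77.8%
compound 3 `C[C@@H]1O[C@@H](OCC#Cc2c(-c3ccccc3)sc3ccccc23)CC[C@@H]1N` — compound 3 gives 7.9%

Compound 3 is the lowest of the three; its values stand beyond the scatter from both compound 1 and compound 2. The one counted step within the set is a number 57.6 percentage points higher from compound 1 to compound 2 (beyond the scatter), brought about by this change: a group of 9 heavy atoms (6 carbon, 1 nitrogen, 2 oxygen; one six-membered non-aromatic ring with 1 hetero atom) in place of a group of 8 heavy atoms (6 carbon, 1 nitrogen, 1 oxygen; one six-membered non-aromatic ring with 1 hetero atom), on an oxygen on a saturated carbon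

Within the data shown here, compound 1 and compound 3 carry different cores; the difference between the two cores is not broken down here, and the two values show only that compound 3 sits lower than compound 1.

Compound 4 `C[C@@H]1O[C@@H](OCC#Cc2c(-c3ccccc3)sc3ccccc23)C[C@H](N)[C@@H]1O` is not yet measured in this assay. It arises from compound 3 by the same change that turns compound 1 into compound 2: a group of 9 heavy atoms (6 carbon, 1 nitrogen, 2 oxygen; one six-membered non-aromatic ring with 1 hetero atom) in place of a group of 8 heavy atoms (6 carbon, 1 nitrogen, 1 oxygen; one six-membered non-aromatic ring with 1 hetero atom), on an oxygen on a saturated carbon

The place of the change reads identically in both pairs. For compound 4 a step of the same kind is expected, a number 47.1 percentage points higher from compound 3 to compound 4 (beyond the scatter). This expectation rests on a number 57.6 percentage points higher from compound 1 to compound 2 (beyond the scatter) and on the low starting point of compound 3 at 7.9%. The estimated value for compound 4 is 55%, with a range from 28% to 78%.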

Compound 4, a percentage reported as inhibition, at one concentration (the size of the read-out at that concentration, not a potency): 36.9%
Compound 4: middle estimate off by 18.1 percentage points, on the high side; the range from low to high includes it.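

In this assay, replacing 5-amino-6-methyloxan-2-yl, on an oxygen on a saturated carbon, with the group of 9 heavy atoms also raises the read-out on the core of compound 3, giving a number 29 percentage points higher from compound 3 to compound 4 (beyond the scatter). The direction of the change therefore carries from one core to the other in these two pairs, but its size does not: the same change on two cores in this assay, a number 57.6 percentage points higher (beyond the scatter) from compound 1 to compound 2 and a number 29 percentage points higher (beyond the scatter) from compound 3 to compound 4, 28.6 percentage points apart, beyond the scatter of two such steps

Two pairs give no rule for any further core, and they do not show what in the two cores sets the size of the step, so a step read on one core gives only its direction on the other, not a reliable size.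

The compounds shown leave open how the amine on the ring bears on the read-out, since every compound here carries the same free amine. On these data alone, whether the step keeps its direction with a dimethylamino group or an acetamide in place of that amine also remains open.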